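Removing the Methyl From Compound 2

The source may report more compounds than this note shows. Statements on the series, on what has been measured and on what is new or still open speak of the compounds shown alone.

Compound 1, `CCc1cccc(NC(=O)c2cccc(/C=C3\CC(=O)N(c4ccccc4)C3=O)c2)c1`: in an ADME assay on HCT-116 cells (Homo sapiens) for cytotoxicity, read by MTT assay, with a stated time of 72 h (on this read-out lower numbers stand for stronger inhibition and higher numbers for weaker inhibition), compound 1 gives 81200 nM.
Compound 2, `COc1ccc(NC(=O)c2cccc(/C=C3\CC(=O)N(c4ccccc4)C3=O)c2)c(C)c1`: in this assay compound 2 reaches only the limit of the assay, > 100000 nM.

Both measured compounds share one core and differ only in the group on the amide-type nitrogen. Among the compounds with values here, the single measured step, an at least 1.2-fold higher number from compound 1 to compound 2 (0.09 log units; that floor lies within the scatter), is a floor that stays within the usual scatter, so it shows no real difference between the two. Compound 2 thus stands at the top of the numbers shown, where no value but only a limit is known, and the limit of > 100000 nM in this assay, at which 1 of the 2 values shown sits, marks that one of the two results is such a limit.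

Compound 3, `COc1ccc(NC(=O)c2cccc(/C=C3\CC(=O)N(c4ccccc4)C3=O)c2)cc1`, differs from compound 2 by a small cut: hydrogen in place of methyl on an aromatic carbon. Within the data shown here, no measured step touches this kind of change, and the only step available carries no signal beyond the scatter. The expectation for compound 3 in this assay is therefore a step of about a number no higher from compound 2 to compound 3 (the limit leaves the size open), that is, none beyond the scatter, with a good chance that again only a limit is returned. Compound 3 is estimated at 100000 nM, within 40000 nM to 300000 nM.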

Compound 3, half-maximal inhibitory concentration: > 100000 nM
Compound 3 ended at the assay's limit (the forecaster's own chance of this, stated with the estimate: 55%); the middle value sits exactly at the limit.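

In this assay compound 3 gives > 100000 nM and that is a limit of the assay and not a number. Compound 2 also returned only a limit, so the step between these two compounds cannot be read, and swapping methyl for hydrogen on this aromatic carbon can be called neither harmful, helpful nor neutral here. The comparison with the 3-ethylphenyl compound, an at least 1.2-fold higher number from compound 1 to compound 3 (0.09 log units; that floor lies within the scatter) and so shows no real difference, and the new result adds only that more of the series now sits at the same ceiling: the limit of > 100000 nM in this assay, at which 2 of the 3 values shown sit.

From the compounds shown here alone, whether compound 2 and compound 3 differ at all remains unknown, as neither has a value that can be placed on the scale. Also open, going by these compounds, is what a group such as an amine or a carboxylic acid on this aromatic carbon would give, and whether any such group would bring a readable number in this assay instead of another limit.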